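The source may hold more compounds than are shown below. What is called first, only, known or untested is meant among the compounds shown, and "the series" means these compounds.

Working notes on a small series sharing one core. In a physicochemical assay, with a stated time of 30 min (a lower number here means a stronger inhibitor, a higher number a weaker inhibitor), compound 1 `CCc1cccc(NC(=O)C2Cc3cc(OC)c(OC)cc3C2=O)c1` gives 64.1 ug/mL and compound 2 `COc1cccc(NC(=O)C2Cc3cc(OC)c(OC)cc3C2=O)c1` gives 38.9 ug/mL. Within the data shown here, compound 2 holds the lower of only two numbers, but the measured step is a 1.6-fold lower number from compound 1 to compound 2 (0.22 log units; within the scatter), so these two compounds cannot be told apart.

Compound 3 `CCOc1cccc(NC(=O)C2Cc3cc(OC)c(OC)cc3C2=O)c1` has not yet been measured. Its difference from compound 2 is methyl in place of hydrogen on a saturated chain carbon bound to an oxygen on an aromatic ring, which reads as methoxy to ethoxy.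

Among the measured compounds shown here, no measured step covers this exchange directly. The nearest evidence is the step between compound 1 and compound 2, methoxy in place of ethyl on an aromatic carbon, which is a different exchange and stayed within the scatter. As far as these compounds go, on that single step, no shift beyond the scatter is expected in this assay, and the direction remains open.

The estimated step is a 1.2-fold higher number from compound 2 to compound 3 (0.06 log units; within the scatter), which is expected to stay within the scatter. For compound 3 the expected value is 45 ug/mL, with an estimated range of 22 ug/mL to 90 ug/mL.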

Compound 3, half-maximal inhibitory concentration: 44.9 ug/mL
For compound 3 the middle estimate is 1.0-fold (0.00 log units) above the measured one, and the stated range covers the measured number.
By their numbers in this assay, from the lowest: compounds 2, 3 and 1 (each within the scatter of the next).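

In this assay, adding the methyl on a saturated chain carbon bound to an oxygen on an aromatic ring, methoxy to ethoxy, gives a 1.2-fold higher number from compound 2 to compound 3 (0.06 log units; within the scatter) and so does not separate the two groups. The exchange of ethyl for ethoxy on an aromatic carbon, which gives a 1.4-fold lower number from compound 1 to compound 3 (0.15 log units; within the scatter), also stays inside the scatter, so compound 3 adds a second group carrying an oxygen that cannot be told apart from ethyl here. Together with the earlier step, this places ethyl, methoxy and ethoxy within the scatter of one another, so in these three compounds neither the added methyl nor the oxygen shows a measurable shift, and no measurement is available that could explain this result.

Still open, as far as these compounds go, is whether a longer chain on the oxygen, such as butoxy, or a different kind of group on the aromatic carbon, such as an amine or a carboxylic acid, would move the number beyond the scatter. Among these compounds, with all three compounds so close, the series so far gives no direction for this position, and a change elsewhere on the shared core remains untested by these compounds.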